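A few compounds are considered here, and "the series" means these few. Any claim that something is new, unique, unknown or untested is made for them only; others in the source may bear on it.

Measured compounds:
Compound 1, `NS(=O)(=O)NC[C@H]1CC[C@H](C(=O)/C(=N/O)Nc2ccc(F)c(Br)c2)CC1`: 21 nM
Compound 2, `O=C(/C(=N/O)Nc1ccc(F)c(Br)c1)C1CCN(C(=O)NCc2ccccc2)CC1`: 28 nM
Compound 3, `O=C(NC[C@H]1CC[C@H](C(=O)/C(=N/O)Nc2ccc(F)c(Br)c2)CC1)c1ccccc1`: 204 nM

The three compounds were measured in an assay on tissue (HeLa cells) for inhibition of Indoleamine 2,3-dioxygenase 1 (Homo sapiens), with a stated time of 48 h; on this read-out lower numbers stand for stronger inhibition and higher numbers for weaker inhibition. Compound 2 stands second highest of the three numbers; its nearest neighbour is compound 1, whose number lies within the scatter of it, while compound 3 sits far above both.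

The unmeasured compound 4, `O=C(/C(=N/O)Nc1ccc(F)c(Br)c1)C1CCN(C(=O)Nc2ccccc2)CC1`, is reached from compound 2 by one change: phenyl in place of benzyl on an amide-type nitrogen. The shared core and the aryl group are untouched.

For the measured compounds named here, no measured step concerns this same change. Going by the values given here, the only step between neighbours, a 9.7-fold higher number from compound 1 to compound 3 (0.99 log units; beyond the scatter), replaces sulfamoyl by benzoyl on an amine nitrogen of a different side chain and so does not bear on trimming benzyl to phenyl on the urea nitrogen. What the data show is that the amide-type nitrogen of compound 2 tolerates a benzylcarbamoyl group at a level close to compound 1. Among the compounds with values here, with no comparable precedent, a step within the scatter is expected, in no particular direction.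

Compound 4 is therefore estimated at 30 nM in this assay, with a range from 12 nM to 80 nM, which corresponds to an expected step of a 1.1-fold higher number from compound 2 to compound 4 (0.03 log units; within the scatter).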

Compound 4, half-maximal inhibitory concentration: 54 nM
Compound 4: the middle estimate sits 1.8-fold (0.26 log units) below what was measured; the range from low to high includes it.
By their numbers in this assay, from the lowest: compounds 1, 2 and 4 (each within the scatter of the next, the first and the last beyond it); then compound 3.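

In this assay, the step from benzyl to phenyl on the amide-type nitrogen is a 1.9-fold higher number from compound 2 to compound 4 (0.29 log units; within the scatter), so this pair gives no measurable separation between benzylcarbamoyl and phenylcarbamoyl at this position. The earlier compounds shown here showed only that this nitrogen could carry benzylcarbamoyl; this pair shows that the six-membered aromatic ring of carbon only can also sit there as anilino rather than benzylamino, with the number staying in the same range. Nothing measured here explains the result or says what the two groups do at this position.

The compounds shown leave open whether a longer chain such as phenylethyl on this nitrogen, a plain methyl without any aromatic ring, or a phenyl ring carrying a carboxylic acid or an amine would keep the number in that range in this assay. From the compounds shown here alone, they also rest this reading on a single pair, so whether the same change behaves alike with another side chain or another aryl group on the shared core remains unknown.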